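A few compounds are considered here, and "the series" means these few. Any claim that something is new, unique, unknown or untested is made for them only; others in the source may bear on it.

Measured compounds:
- compound 2, `COc1ccc(Cc2nn(C(C)(C)C)c(=O)c3ccccc23)cc1OC`: 10000 nM
- compound 1, `CSc1ccc(Cc2nn(-c3ccc([N+](=O)[O-])cc3)c(=O)c3ccccc23)cc1`: limit, > 100000 nM

Among the compounds with values here, in a functional assay on aorta with Alpha-1D adrenergic receptor (Rattus norvegicus) as the target (a lower number here means that less compound is needed, a higher number that more compound is needed for the effect), compound 2 gives 10000 nM and is the only compound of the two with a number. Compound 1, measured in this assay, gives > 100000 nM, which is a limit of the assay and not a number; (the limit of > 100000 nM in this assay, at which 1 of the 2 values shown sits). Within the data shown here, no step between measured compounds that differ in a single place is available, so the two values show only that compound 2 sits at a number and compound 1 at a limit.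

Compound 3, `COc1ccc(Cc2nn(-c3ccc(Br)cc3)c(=O)c3ccccc23)cc1OC`, is not yet measured in this assay. It differs from compound 2 in one place: 4-bromophenyl in place of tert-butyl on an aromatic nitrogen. Compound 1 also carries an aryl group on that aromatic nitrogen, though it differs from compound 3 elsewhere as well, so its limit cannot be turned into a step. The writer expects the change from compound 2 to compound 3 to move the value toward weaker potency, beyond the usual scatter, as a 3.0-fold higher number from compound 2 to compound 3 (0.48 log units; beyond the scatter). The estimate for compound 3 in this assay is 30000 nM, with a range from 5000 nM to 100000 nM.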

Compound 3, half-maximal effective concentration: > 100000 nM
Compound 3 ended at the assay's limit; the forecaster's own chance of this, stated with the estimate: 40%; middle value at least 3.3-fold (0.52 log units) away from the limit.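

Within the data shown here, the single change from tert-butyl to 4-bromophenyl on the aromatic nitrogen gives, in this assay, an at least 10-fold higher number from compound 2 to compound 3 (1.00 log units; beyond the scatter), the first step that can be read at this position. Compound 3 gives > 100000 nM, which is a limit of the assay and not a number, so only a lower bound on the size of the step is known. Compound 1 and compound 3, which both carry an aryl group on that nitrogen but also differ elsewhere, sit at the same limit, leaving compound 2, with tert-butyl, as the only compound with a number: the limit of > 100000 nM in this assay, at which 2 of the 3 values shown sit.

The compounds shown leave open whether a methyl group, a cyclohexyl ring or a plain phenyl ring on that nitrogen would still give a number in this assay. They also leave open whether the step comes from the aromatic ring itself or from its bromine, and these values give no reason for it.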